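The source may report more compounds than this note shows. Statements on the series, on what has been measured and on what is new or still open speak of the compounds shown alone.

Measured so far, in the assay that follows:
compound 1 `O=C(NO)c1cccc(-c2cn([C@@H]3C[C@H](C(=O)O)N(CCCc4ccccc4)C3)nn2)c1`: < 10% (a limit)
compound 2 `O=C(/C=C/c1cn([C@H]2C[C@@H](C(=O)O)N(CCCc3ccccc3)C2)nn1)NO`: 29%
compound 3 `O=C(NO)c1ccc(-c2cn([C@@H]3C[C@H](C(=O)O)N(CCCc4ccccc4)C3)nn2)cc1`: < 10% (a limit)

Compound 3 stands at the lower limit of an assay on Sf9 cells for inhibition of histone deacetylase 11 (Homo sapiens), read by fluorescence, tested at 0.5 uM (on this read-out higher numbers stand for more inhibition at the one concentration tested (going by the name of the read-out) and lower numbers for less inhibition), since in this assay compound 3 gives only < 10%. Compound 1 sits at the same limit, so the step that the two limits leave unreadable from compound 1 to compound 3 cannot be read, as noted in the limit of < 10% in this assay, at which 2 of the 3 values shown sit. Among the compounds with values here, compound 2 is the one member of the series with a number: in this assay compound 2 gives 29%.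

The next compound, compound 4 `O=C(/C=C/c1cn([C@@H]2C[C@H](C(=O)O)N(CCCc3ccccc3)C2)nn1)NO`, differs from compound 3 in one place: 2-(hydroxycarbamoyl)ethenyl in place of 4-(hydroxycarbamoyl)phenyl on an aromatic carbon

Within the data shown here, no measured step covers this change, because the only read step is a step that the two limits leave unreadable from compound 1 to compound 3 and it moves the hydroxycarbamoyl group around the phenyl ring rather than exchanging the phenyl for the ethenyl linker. The only point of reference is compound 2, which carries the same 2-(hydroxycarbamoyl)ethenyl group on its core and gives 29% in this assay. Going by these compounds, on that basis an upward step a number at least 12 percentage points higher from compound 3 to compound 4 (beyond the scatter) is expected for compound 4, though with compound 3 at a limit its true size stays open. Compound 4 is estimated at 22% in this assay, with a range from 6% to 38%.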

Compound 4, a percentage reported as inhibition, at one concentration (the size of the read-out at that concentration, not a potency): 11%
Compound 4: middle estimate off by 11 percentage points, on the high side; the range from low to high includes it.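

In this assay the series now holds one step beyond the scatter, a number 18 percentage points lower from compound 2 to compound 4 (beyond the scatter), and it can be laid to the drawn configuration at the two saturated ring carbons alone, so the 2-(hydroxycarbamoyl)ethenyl group does not fix the read-out by itself, because of this: the fact that compounds 2 and 4 differ only in the configuration as drawn. With the configuration of compound 4, exchanging a hydroxycarbamoyl-substituted phenyl for the 2-(hydroxycarbamoyl)ethenyl group gives a number at least 1 percentage points higher from compound 3 to compound 4 (that floor lies within the scatter) and also a number at least 1 percentage points higher from compound 1 to compound 4 (that floor lies within the scatter), so on this configuration the exchange is not shown to raise the read-out beyond the scatter. Going by these compounds, both of these steps start from a value that is a limit, so their true size stays open: the limit of < 10% in this assay, at which 2 of the 4 values shown sit.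

The compounds shown leave open whether the configuration of compound 2 would also raise the read-out with 4-(hydroxycarbamoyl)phenyl or 3-(hydroxycarbamoyl)phenyl on the aromatic carbon, and which of the two ring stereocentres carries the step. Also open, on these data alone, is how a longer chain between the aromatic carbon and the hydroxycarbamoyl group would read on either configuration.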